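Working notes: the step from compound 2 to compound 3

The source may hold more compounds than are shown below. What is called first, only, known or untested is meant among the compounds shown, and "the series" means these compounds.

In a physicochemical assay for lipophilicity, using the shake flask method, in phosphate buffer, measured as octanol-water partition, with a stated time of 24 h, at pH 7.4, tested at 100 uM (on this read-out lower numbers stand for lower lipophilicity and higher numbers for higher lipophilicity), compound 2 (`Cc1ccccc1-c1cccc(COc2ccc(S(=O)(=O)CC(=O)O)cc2)c1`) gives 2.35, within the scatter of compound 1 (`COc1cc(C)c(-c2cccc(COc3ccc(S(=O)(=O)CC(=O)O)cc3)c2)c(C)c1`) at 2.45. Compound 3 (`O=C(O)CS(=O)(=O)c1ccc(OCc2cccc(-c3ccccc3)c2)cc1`) carries hydrogen in place of methyl on an aromatic carbon, ortho to a large group: hydrogen in place of methyl on an aromatic carbon. Going by the values given here, the one measured step that bears on this, a number 0.10 log units lower from compound 1 to compound 2 (within the scatter), put 2-methylphenyl in place of 4-methoxy-2,6-dimethylphenyl and stayed within the scatter. In this assay, the expected step is similarly small and slightly downward, not beyond the scatter: a number 0.10 log units lower from compound 2 to compound 3 (within the scatter). The estimate for compound 3 is 2.25, with an expected range of 1.95 to 2.55.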

Compound 3, distribution coefficient: 2.13
For compound 3 the middle estimate is 0.12 log units above the measured one; low and high end bracket the measured number.
By their numbers in this assay, from the lowest: compounds 3, 2 and 1 (each within the scatter of the next, the first and the last beyond it).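

In this assay, hydrogen in place of methyl on this aromatic carbon gives a number 0.22 log units lower from compound 2 to compound 3 (within the scatter) and so adds a second small step at this position. Phenyl in place of 4-methoxy-2,6-dimethylphenyl gives a number 0.32 log units lower from compound 1 to compound 3 (beyond the scatter) and is the only step in the series that passes the scatter. Nothing available explains either step. Still open, on these data alone, is how a carboxylic acid or an amine at this position would read, and whether a longer chain in place of methyl would stay within the scatter of compound 2.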